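Acetyl to dimethylamino: a single change from compound 1

A few compounds are considered here, and "the series" means these few. Any claim that something is new, unique, unknown or untested is made for them only; others in the source may bear on it.

Working notes on compound 1 `COc1cc(C)cc(-c2c(-c3ccnc(-c4ccc(C(C)=O)cc4)c3)cnn2CC#N)c1` and its single-change analogue compound 3 `COc1cc(C)cc(-c2c(-c3ccnc(-c4ccc(N(C)C)cc4)c3)cnn2CC#N)c1`. In a functional assay on A549 cells (Homo sapiens) for inhibition, read by sulforhodamine B assay, with a stated time of 48 h (a lower number here means a stronger inhibitor of growth, a higher number a weaker inhibitor of growth), compound 1 gives only a limit, > 100000 nM, so its standing on the numbers is not fixed. Within the data shown here, the other measured member is compound 2 `COc1cc(C)cc(-c2nn(CC#N)cc2-c2ccc(-c3cccc(C(C)=O)c3)nc2)c1`, which in this assay gives 30800 nM; no single-change step joins it to compound 1, so the two values simply stand side by side. What the measured data offer is the limit of > 100000 nM in this assay, at which 1 of the 2 values shown sits, and nothing more. The change to compound 3 is dimethylamino in place of acetyl on an aromatic carbon; cut one bond further out it reads 4-acetylphenyl to 4-(dimethylamino)phenyl. Among the measured compounds shown here, no measured step guides this move. From compound 1 the step is expected to be an at least 1.6-fold lower number from compound 1 to compound 3 (0.22 log units; that floor lies within the scatter), most likely nothing beyond the scatter, with a modest gain as the outside chance. Compound 3 is therefore estimated at 60000 nM, with a range from 15000 nM to 100000 nM, and a fair chance that only a limit is again reported.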

Compound 3, concentration for total growth inhibition: > 100000 nM
Compound 3: no number, only a limit (the forecaster's own chance of this, stated with the estimate: 50%); middle value at least 1.6-fold (0.22 log units) from the limit.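

In this assay, among these compounds, compound 1 and compound 3 each give only a limit, so no step between them can be read. The compounds shown leave open whether dimethylamino in place of acetyl changes growth inhibition at all, and in which direction.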